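Compound 3: a larger side chain on the oxygen

The compounds below may be only part of what the source reports. "The series", "measured", "known", "first", "only" and "open" are said of these compounds alone.

In a physicochemical assay for solubility, read by nephelometry, measured as kinetic solubility, with a stated time of 30 min (a higher number here means a more soluble compound, a lower number a less soluble compound), compound 1 (`c1cc([C@H]2CC[C@]3(CC2)OOC2(O3)C3CC4CC(C3)CC2C4)ccc1OCCC1CCNCC1`) gives > 100 ug/mL, a limit of the assay. Compound 2 (`CC(C)(CN)Oc1ccc([C@H]2CC[C@]3(CC2)OOC2(O3)C3CC4CC(C3)CC2C4)cc1`) gives > 100 ug/mL, also a limit and not a number. Both compounds therefore stand at the limit of > 100 ug/mL in this assay, at which 2 of the 2 values shown sit. Compound 3 (`O[C@H]1CC[C@H](NCCCOc2ccc([C@H]3CC[C@]4(CC3)OOC3(O4)C4CC5CC(C4)CC3C5)cc2)CC1`) carries 3-((4-hydroxycyclohexyl)amino)propyl in place of 1-(aminomethyl)-1-methylethyl on an oxygen on an aromatic ring. Within the data shown here, the only measured step, a step that the two limits leave unreadable from compound 1 to compound 2, gives no size to carry over, so no change beyond the scatter is expected in this assay. The expected step is a number no higher from compound 2 to compound 3 (the limit leaves the size open), with no direction readable. Compound 3 is estimated at 100 ug/mL, with a range of 40 ug/mL to 150 ug/mL.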

Compound 3, solubility: > 100 ug/mL
Compound 3 was reported as a limit; the forecaster's own chance of this, stated with the estimate: 65%; the middle value sits exactly at the limit.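

Compound 1, compound 2 and compound 3 share one limit, so no step among them can be read: the limit of > 100 ug/mL in this assay, at which 3 of the 3 values shown sit.

On these data alone, still open in this assay is how far the solubility of each compound lies past that limit, and whether these side chains differ at all.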